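The source may hold more compounds than are shown below. What is called first, only, known or untested is meant among the compounds shown, and "the series" means these compounds.

Of the compounds shown here, three have so far been measured in an ADME assay on Huh-7 cells (Homo sapiens) for cytotoxicity; a lower number here means that less compound is tolerated, a higher number that more compound is tolerated. Compound 1 `O=C(NC(=S)n1ccc2c(OCCCCCOc3ccc(Cl)cc3)cccc21)c1ccccc1` gives 29500 nM in this assay. Compound 2 `O=C(NC(=S)N1CCc2ccc(OCc3ccccc3)cc21)c1ccccc1` gives 43800 nM in this assay. Compound 3 `O=C(NC(=S)N1CCc2c(OCCCCCOc3ccc(Cl)cc3)cccc21)c1ccc([N+](=O)[O-])cc1` gives 13600 nM in this assay, the lowest of the three numbers, meaning the cells tolerate less of it than of the other two; its gap to compound 1 lies beyond the usual scatter of repeated measurements, and its gap to compound 2 is wider still.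

Compound 4 `O=C(NC(=S)N1CCc2c(OCCCCCOc3ccc(Cl)cc3)cccc21)c1ccc(Cl)cc1` has not yet been measured. It differs from compound 3 in a single place: chloro in place of nitro on an aromatic carbon. Among the compounds with values here, no pair among the measured compounds isolates this exchange, so nothing measured here shows how large such a swap is. Compound 1 and compound 2 both lack the nitro group and both give higher numbers than compound 3, but each also differs from it elsewhere, so that comparison is only a loose hint.

For compound 4 a modest rise in this assay is expected, with a 1.5-fold higher number from compound 3 to compound 4 (0.17 log units; within the scatter) likely small enough to sit near the edge of the scatter. The estimate for compound 4 in this assay is 20000 nM, expected to fall between 8000 nM and 50000 nM.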

Compound 4, half-maximal cytotoxic concentration: 21700 nM
Beside the measured number, compound 4's estimate is 1.1-fold (0.04 log units) below it; measured number inside the range.
By their numbers in this assay, from the lowest: compounds 3, 4, 1 and 2 (each within the scatter of the next, the first and the last beyond it).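

Within the data shown here, replacing the 4-nitrophenyl group with 4-chlorophenyl gives the first direct reading of this exchange in this assay: a 1.6-fold higher number from compound 3 to compound 4 (0.20 log units; within the scatter). At this place on the ring, para to a large group, nitro with its 3 heavy atoms and 2 hydrogen-bond acceptors can therefore give way to chloro, a single heavy atom with no acceptors, and the two compounds cannot be told apart in this read-out. The nitro group is thus not shown to be needed for the number seen with compound 3, and nothing available here bears on why the exchange makes so little visible difference.

This is a single pair, so it cannot show whether the same exchange would read the same way on another core, such as that of compound 1 or compound 2. It also leaves open how the cells would tolerate a different group on this aromatic carbon, such as an amine, a carboxylic acid or a methoxy group, any of which might give a step beyond the scatter.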